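Replacing 4-chlorophenyl with 4-methoxyphenyl: working notes

The source may report more compounds than this note shows. Statements on the series, on what has been measured and on what is new or still open speak of the compounds shown alone.

In a functional assay on PC-3 cells (Homo sapiens) for inhibition, read by MTT assay, with a stated time of 48 h (a lower number here means a stronger inhibitor, a higher number a weaker inhibitor), compound 1 (`C[C@H]1CCC/C=C/[C@H]2CC[C@H](O)[C@@H](CC(=O)O1)O2`) stands as "not determined" (no result reported) and compound 2 (`C[C@H]1CCC/C=C/[C@H]2CC[C@H](O)[C@H](CC(=O)O1)O2`) stands as "not determined" (no result reported) in the results, so neither offers a comparison. Among the compounds with values here, compound 3 (`CCO[C@H]1C=C[C@H]2C/C=C\C[C@H](c3ccc(Cl)cc3)OC(=O)C[C@@H]1O2`) gives 9160 nM in this assay and holds the only number so far. Compound 4 (`CCO[C@H]1C=C[C@H]2C/C=C\C[C@H](c3ccc(OC)cc3)OC(=O)C[C@@H]1O2`) carries methoxy in place of chloro on an aromatic carbon, para to a large group (methoxy in place of chloro on an aromatic carbon), with the rest of the structure unchanged. Within the data shown here, no measured step is available to size this change, so the expectation rests on compound 3 at 9160 nM alone, with no direction favoured. The estimated step of a 1.1-fold higher number from compound 3 to compound 4 (0.04 log units; within the scatter) is expected to stay within the usual scatter. Compound 4 is expected at 10000 nM with a range of 3500 nM to 28000 nM in this assay once measured.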

Compound 4, half-maximal inhibitory concentration: 56000 nM
For compound 4 the middle estimate is 5.6-fold (0.75 log units) below the measured one; measured number outside the range, above it.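

In this assay, within the data shown here, the swap of chloro for methoxy gives a 6.1-fold higher number from compound 3 to compound 4 (0.79 log units; beyond the scatter), the first sized step, and it makes compound 4 the weaker inhibitor of the pair. The aromatic carbon para to a large group is therefore not indifferent to what it carries: this single change moves the number beyond the scatter. Nothing in the evidence at hand bears on why this step occurs.

The compounds shown leave open how an amine or a bare hydrogen at this place would compare with chloro and methoxy. As far as these compounds go, with one step, it also remains open whether the same swap would act alike on another core.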